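The source may report more compounds than this note shows. Statements on the series, on what has been measured and on what is new or still open speak of the compounds shown alone.

Measured compounds and their values in a functional assay on SK-N-SH cells (Homo sapiens) for inhibition, read by MTT assay; a lower number here means a stronger inhibitor, a higher number a weaker inhibitor:
- compound 1, `CCCCCCCCn1cc(/C=C/C(=O)c2ccc(NC(=O)CN3CCN(c4ccccc4)CC3)cc2)nn1`: 41400 nM
- compound 2, `O=C(CN1CCN(c2ccccc2)CC1)Nc1ccc(C(=O)/C=C/c2cn(Cc3ccc(Br)cc3)nn2)cc1`: 72400 nM
- compound 3, `CCCCCCCCn1cc(/C=C/C(=O)c2ccc(NC(=O)CBr)cc2)nn1`: 8460 nM

Compound 1 gives the second highest of the three numbers. Its nearest neighbour is compound 2, where a 1.7-fold higher number from compound 1 to compound 2 (0.24 log units; within the scatter); the furthest is compound 3, where a 4.9-fold lower number from compound 1 to compound 3 (0.69 log units; beyond the scatter).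

Compound 4, `CCCCCCCCn1cc(/C=C/C(=O)c2ccc(NC(=O)CN3CCN(c4ccccc4OC)CC3)cc2)nn1`, differs from compound 1 in one place: methoxy in place of hydrogen on an aromatic carbon. Read one bond further out, this is phenyl to 2-methoxyphenyl.

Neither measured step bears directly on this change. The step from compound 1 to compound 2 alters the group on the triazole nitrogen and stays within the scatter; the step from compound 1 to compound 3 removes the whole phenylpiperazine and gives a modest lowering. Nothing measured probes a substituent on the phenyl of the phenylpiperazine, so there is no ground for expecting a shift beyond the scatter in this assay. The expected step is a 1.1-fold lower number from compound 1 to compound 4 (0.04 log units; within the scatter), that is, essentially none beyond the scatter.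

Compound 4 is therefore estimated at 38000 nM in this assay, with a range from 15000 nM to 95000 nM.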

Compound 4, half-maximal inhibitory concentration: 21500 nM
Estimate against measurement, compound 4: 1.8-fold (0.25 log units) above; low and high end bracket the measured number.
By their numbers in this assay, from the lowest: compound 3; then compounds 4, 1 and 2 (each within the scatter of the next, the first and the last beyond it).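

In this assay the step reads a 1.9-fold lower number from compound 1 to compound 4 (0.28 log units; within the scatter) and so stays within the scatter, with methoxy on an aromatic carbon, ortho to a large group, on the outer phenyl of the phenylpiperazine. Among these compounds, this is the first reading of a substituent on that phenyl: the earlier steps changed the group on the aromatic nitrogen or removed the phenylpiperazine altogether, whereas here the phenylpiperazine stays whole and gains 2 heavy atoms with no shift that can be told from the scatter. No measurement offered here accounts for this step or for its direction.

Still open, on these data alone, is whether a different group on the same aromatic carbon, such as a hydroxy group, a chlorine atom, an amine or a carboxylic acid, would also stay within the scatter or move the number beyond it. Also open, as far as these compounds go, is whether the methoxy step would read the same on the core of compound 2, which carries the 4-bromophenyl group on the chain carbon bound to the aromatic nitrogen.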